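Changing the Aryl Group on a Shared Core

The source may hold more compounds than are shown below. What is called first, only, known or untested is meant among the compounds shown, and "the series" means these compounds.

Compound 2 `CCCS(=O)(=O)Nc1ccc(F)c(C(=O)c2n[nH]c3ncc(-c4ccc(C(C)C)cc4)cc23)c1F` gives 17% in an assay for binding affinity to dual specificity mitogen-activated protein kinase kinase 4 (Homo sapiens), read by KINOMEscan, tested at 100 nM; a higher number here means a weaker effect of the compound at the concentration tested, a lower number a stronger effect. On the numbers shown it cannot be separated from compound 1 `CCCS(=O)(=O)Nc1ccc(F)c(C(=O)c2n[nH]c3ncc(-c4ccccc4N)cc23)c1F`, which gives 23%, since the step of a number 6 percentage points lower from compound 1 to compound 2 (within the scatter). Compound 3 `CCCS(=O)(=O)Nc1ccc(F)c(C(=O)c2n[nH]c3ncc(-c4cccc(C(F)(F)F)c4)cc23)c1F` differs from compound 2 by 3-(trifluoromethyl)phenyl in place of 4-isopropylphenyl on an aromatic carbon. Among the measured compounds shown here, the one measured step that bears on this, an exchange of one aromatic group for another, stayed within the scatter, so the step of a number 4 percentage points higher from compound 2 to compound 3 (within the scatter) is expected to stay within the scatter as well. Compound 3 is therefore estimated at 21%, in a range from 6% to 40%.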

Compound 3, a percentage reported as activity, at one concentration (the size of the read-out at that concentration, not a potency): 57%
Beside the measured number, compound 3's estimate is 36 percentage points below it, and the stated range ends below it.
By their numbers in this assay, from the lowest: compounds 2 and 1 (each within the scatter of the next); then compound 3.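

In this assay, the aromatic group at this position of the shared core clearly matters: 3-(trifluoromethyl)phenyl gives a number 40 percentage points higher from compound 2 to compound 3 (beyond the scatter) and a number 34 percentage points higher from compound 1 to compound 3 (beyond the scatter), a weaker effect at the concentration tested. The earlier exchange of 2-aminophenyl for 4-isopropylphenyl stayed within the scatter, so one aromatic group cannot always stand in for another here. Nothing at hand explains this loss. Still open, as far as these compounds go, is whether the trifluoromethyl group itself or its place on the ring decides the outcome, and how a plain phenyl group or a 4-(trifluoromethyl)phenyl group would compare.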